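Butyl in Place of Isopropyl on the Aryl Ring

A few compounds are considered here, and "the series" means these few. Any claim that something is new, unique, unknown or untested is made for them only; others in the source may bear on it.

Among the compounds with values here, compound 2 `CC(C)c1ccc(/C=C/C(=O)Nc2ccc3c(c2)OCCO3)cc1` stands as the stronger of the two compounds measured so far in a functional assay on CHO cells for inhibition of transient receptor potential cation channel subfamily V member 1 (Homo sapiens) (a lower number here means a stronger inhibitor, a higher number a weaker inhibitor), where compound 2 gives 82 nM. Compound 1 `Cc1ccc(/C=C/C(=O)Nc2ccc3c(c2)OCCO3)cc1` gives 1100 nM. Within the data shown here, the only measured step, a 13-fold lower number from compound 1 to compound 2 (1.13 log units; beyond the scatter), shows that exchanging methyl for isopropyl at this position went with a much lower number. Compound 3 `CCCCc1ccc(/C=C/C(=O)Nc2ccc3c(c2)OCCO3)cc1` carries a further exchange at the same position: butyl in place of isopropyl on an aromatic carbon. That single step bears on it only loosely, since it compared methyl with isopropyl rather than isopropyl with butyl, but it indicates that such exchanges at this carbon are tolerated. A step is therefore expected that is small, at most a modest lowering, and the expected step is a 1.4-fold lower number from compound 2 to compound 3 (0.14 log units; within the scatter). Compound 3 is estimated at 60 nM, within an expected range from 20 nM to 200 nM.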

Compound 3, half-maximal inhibitory concentration: 2700 nM
Compound 3: the middle estimate sits 45-fold (1.65 log units) below what was measured, outside the stated range (above it).
By their numbers in this assay, from the lowest: compound 2; then compound 1; then compound 3.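

In this assay, this position proves highly sensitive to the exact group it carries: exchanging isopropyl for butyl adds only one carbon to the count, yet it gives a 33-fold higher number from compound 2 to compound 3 (1.52 log units; beyond the scatter) as the step. Butyl also does worse than the much smaller methyl (a 2.5-fold higher number from compound 1 to compound 3 (0.39 log units; beyond the scatter)), so the number does not fall steadily as carbons are added, and compound 2 stands out as the strongest of the three, with compound 3 the weakest. No measurement at hand explains why butyl and isopropyl differ so sharply.

From the compounds shown here alone, whether the sharp change follows chain length or the shape of the group stays open, as a straight propyl chain or a tert-butyl group could help to separate these two readings. Going by these compounds, how a methoxy group or an amine at this carbon would compare also remains unknown.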